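A few compounds are considered here, and "the series" means these few. Any claim that something is new, unique, unknown or untested is made for them only; others in the source may bear on it.

Values in a functional assay on HCT-8 cells (Homo sapiens) for antiproliferative activity, read by MTT assay, with a stated time of 48 h (on this read-out higher numbers stand for weaker inhibition and lower numbers for stronger inhibition), for the measured compounds:

- compound 1 `COc1ccc(C(=O)c2ccc(OC)c3c2OC(C)(C)C=C3)c(NC(=O)CN(C)C)c1` gives 1590 nM
- compound 2 `C=C(c1ccc(OC)cc1NC(=O)CO)c1ccc(OC)c2c1C=CC(C)(C)O2` gives 470 nM
- compound 3 `C=C(c1cc(OC)c(OC)c(OC)c1)c1ccc(OC)cc1NC(=O)CO` gives 40 nM

Compound 2 sits in the middle of this short series. Compound 1 has a higher number and so inhibits more weakly, while compound 3 has a lower number and inhibits more strongly. Both gaps lie beyond the usual scatter.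

The next compound to be tested is compound 4 `C=C(c1ccc(OC)cc1NC(=O)CN(C)C)c1ccc(OC)c2c1C=CC(C)(C)O2`, which keeps the structure of compound 2 except for one group. It has dimethylamino in place of hydroxy on a saturated chain carbon bound to a carbonyl carbon and has not yet been measured.

Among the compounds with values here, no measured pair shows this change on its own. Compound 1 also carries the dimethylamino group and gives 1590 nM in this assay but differs from compound 4 elsewhere too, so it is only a loose guide. A small shift toward weaker inhibition is therefore expected, probably not beyond the scatter. The expected change is a 1.3-fold higher number from compound 2 to compound 4 (0.11 log units; within the scatter) in this assay. For compound 4 the estimate is 600 nM with an expected range from 150 nM to 2400 nM in this assay.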

Compound 4, half-maximal inhibitory concentration: 1920 nM
Estimate against measurement, compound 4: 3.2-fold (0.51 log units) below; the measured number falls inside the stated range.
By their numbers in this assay, from the lowest: compound 3; then compound 2; then compounds 1 and 4 (each within the scatter of the next).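

In this assay, within the data shown here, the change from hydroxy to dimethylamino on a saturated chain carbon bound to a carbonyl carbon gives a 4.1-fold higher number from compound 2 to compound 4 (0.61 log units; beyond the scatter), the first reading of this swap with the rest of the molecule held the same, and it shows that inhibition is sensitive to the group at this position. With dimethylamino in place, compound 4 at 1920 nM and compound 1 at 1590 nM lie within the usual scatter of each other, although the two compounds differ elsewhere in their structures. Nothing shown here gives a measured reason for the step, so its cause remains unknown.

The swap removes a hydrogen-bond donor and adds two heavy atoms overall, and these compounds cannot separate the loss of hydroxy from the arrival of dimethylamino; a methoxy or a plain amino group at the same place would help to tell these apart. From the compounds shown here alone, it also remains open whether dimethylamino would bring a similar step on the core of compound 3, which carries hydroxy and gives 40 nM.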